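Three Compounds at One Limit and an Expected Fourth

This account rests on a few compounds, and the source may have more. Where it says the series, first, only, none or still open, it means among the compounds named here.

Compound 1 `CC(C)(C)C#Cc1cc(N(C(=O)[C@H]2CC[C@H](C)CC2)[C@H]2CC[C@H](OC3CCOC3)CC2)c(C(=O)O)s1`, compound 2 `CC(C)(C)C#Cc1cc(N(C(=O)[C@H]2CC[C@H](C)CC2)[C@H]2CC[C@@H](Oc3ccc(=O)[nH]n3)CC2)c(C(=O)O)s1` and compound 3 `C[C@H]1CC[C@H](C(=O)N(c2cc(C#CC3(C(F)(F)F)CC3)sc2C(=O)O)[C@H]2CC[C@H](Oc3ccc(=O)[nH]n3)CC2)CC1` were tested in an ADME assay on MT4 cells (Homo sapiens) for cytotoxicity, with a stated time of 5 days; on this read-out higher numbers stand for lower toxicity in this test and lower numbers for higher toxicity in this test. Compound 1 gives > 20000 nM, which is a limit of the assay rather than a number. Compound 2 likewise gives only the limit > 20000 nM. Compound 3 stands at the limit > 20000 nM as well. All three measured values therefore sit at the limit of > 20000 nM in this assay, at which 3 of the 3 values shown sit, and none of the three can be set apart from the others. Compound 4 `CC(C)(C)C#Cc1cc(N(C(=O)[C@H]2CC[C@H](C)CC2)[C@H]2CC[C@H](Oc3ccc(=O)[nH]n3)CC2)c(C(=O)O)s1` has not yet been measured; it differs from compound 3 by tert-butyl in place of 1-(trifluoromethyl)cyclopropyl on a triple-bonded carbon. For the measured compounds named here, no step between measured compounds covers this change. Compound 4 is expected to show no shift beyond the usual scatter, a step that the limit leaves unreadable from compound 3 to compound 4. This expectation rests on compound 1, compound 2 and compound 3 all sitting at the limit of > 20000 nM in this assay, at which 3 of the 3 values shown sit. Compound 4 is thus estimated at 30000 nM, with a range from 20000 nM to 80000 nM, most likely reported again as a limit.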

Compound 4, half-maximal cytotoxic concentration: > 20000 nM
Compound 4 ended at the assay's limit; the forecaster's own chance of this, stated with the estimate: 85%; the middle value is on the limit's open side.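

For the compounds shown here, compound 4 gives only a limit, as do compound 1, compound 2 and compound 3, so no step among them can be read: the limit of > 20000 nM in this assay, at which 4 of the 4 values shown sit. The compounds shown leave open whether any of these changes shifts toxicity in this assay.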